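The source may hold more compounds than are shown below. What is called first, only, known or untested is meant among the compounds shown, and "the series" means these compounds.

Within the data shown here, compound 3 `CCN1C(=O)CSC1c1cccc(C(=O)NCCCCc2ccccc2)c1` gives 40% in a functional assay on 143B cells (Homo sapiens) for inhibition, read by CCK-8 assay, with a stated time of 72 h, tested at 1 uM (a higher number here means more inhibition at the concentration tested (going by the name of the read-out), a lower number less inhibition), which is the second highest of the three numbers measured so far. Compound 2 `O=C(NCCCCc1ccccc1)c1cccc(C2SCC(=O)N2c2cccc(F)c2)c1` gives 63% in this assay, and compound 1 `COc1ccc(C)cc1N1C(=O)CSC1c1cccc(C(=O)NCCCCc2ccccc2)c1` gives 29% in this assay. Compound 4 `O=C(NCCCCc1ccccc1)c1cccc(C2SCC(=O)N2c2ccccc2)c1` has not been measured yet and differs from compound 3 in one place: phenyl in place of ethyl on an amide-type nitrogen in a ring. Among the measured compounds shown here, two measured steps bear on this change, since each exchanges the ethyl on the same ring nitrogen against an aromatic ring. There was a number 23 percentage points lower from compound 2 to compound 3 (beyond the scatter), and there was a number 11 percentage points higher from compound 1 to compound 3 (beyond the scatter). Going from ethyl to an aromatic ring has thus moved the number in both directions by modest to large amounts, depending on what the aromatic ring carries; a plain phenyl carries none of the substituents seen on compound 1 or compound 2. The estimated step is a number 12 percentage points higher from compound 3 to compound 4 (beyond the scatter), placing compound 4 between the two aromatic cases already measured. The estimate for compound 4 in this assay is 52%, with a range from 33% to 70%.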

Compound 4, a percentage reported as inhibition, at one concentration (the size of the read-out at that concentration, not a potency): 60%
Estimate against measurement, compound 4: 8 percentage points below; the range from low to high includes it.
By their numbers in this assay, from the lowest: compound 1; then compound 3; then compounds 4 and 2 (each within the scatter of the next).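

In this assay, a bare phenyl on the ring nitrogen already gives a higher number than ethyl, with a number 20 percentage points higher from compound 3 to compound 4 (beyond the scatter), so the aromatic ring needs no substituent for this gain. The fluoro of compound 2 adds nothing that can be told apart, with a number 3 percentage points lower from compound 2 to compound 4 (within the scatter), and the pair reads as equal. The low number of compound 1 therefore goes with the added groups of the 2-methoxy-5-methylphenyl ring rather than with having an aromatic ring there, as shown by a number 31 percentage points higher from compound 1 to compound 4 (beyond the scatter).

Nothing available explains why phenyl gives more inhibition than ethyl at this nitrogen. Going by these compounds, it also stays open whether the methoxy or the methyl accounts for the loss, and whether a longer chain such as butyl, or a phenyl carrying an amine or a carboxylic acid, would keep the gain.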